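A few compounds are considered here, and "the series" means these few. Any claim that something is new, unique, unknown or untested is made for them only; others in the source may bear on it.

Working notes on the aminothiophene series. Compound 1 `Nc1scc(CN2CCN(c3ccc(Cl)cc3F)CC2)c1C(=O)c1ccc(Cl)cc1` gives -81% in a functional assay on CHO cells with adenosine receptor A1 (Homo sapiens) as the target, read by cAMP accumulation and immunoassay, with a stated time of 6 min, tested at 10 uM; a lower number here means a stronger effect, a higher number a weaker effect of the compound at the concentration tested. Among the compounds with values here, compound 2 `Nc1scc(CN2CCN(c3ccccc3C(F)(F)F)CC2)c1C(=O)c1ccc(Cl)cc1` gives -60% in this assay, which is the higher of the two numbers measured so far; its nearest neighbour is compound 1, reached by the step of a number 21 percentage points higher from compound 1 to compound 2 (beyond the scatter), where only the aryl group on the ring amine nitrogen was exchanged. Compound 3 `Nc1scc(CN2CCN(c3cccnc3)CC2)c1C(=O)c1ccc(Cl)cc1` is not yet measured. It differs from compound 2 in pyridin-3-yl in place of 2-(trifluoromethyl)phenyl on an amine nitrogen in a ring. Within the data shown here, the only measured step that bears on this change is the one from compound 1 to compound 2, also an exchange of the aryl group at the same ring nitrogen, and it moved the number by a modest amount. Among the measured compounds shown here, no measured pair shows a pyridin-3-yl at this position, so the direction of the new step cannot be read from the data. The expectation for compound 3 is therefore a step of a number 2 percentage points lower from compound 2 to compound 3 (within the scatter), within the scatter, with a wide range. Compound 3 is estimated at -62%, between -85% and -35%.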

Compound 3, a percentage reported as activity, at one concentration (the size of the read-out at that concentration, not a potency): -23%
Beside the measured number, compound 3's estimate is 39 percentage points below it; measured number outside the range, above it.
By their numbers in this assay, from the lowest: compound 1; then compound 2; then compound 3.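

In this assay the aryl group on the ring amine nitrogen proves able to move the read-out much further than the earlier exchange showed: pyridin-3-yl in place of 2-(trifluoromethyl)phenyl gives a number 37 percentage points higher from compound 2 to compound 3 (beyond the scatter) and in place of 4-chloro-2-fluorophenyl gives a number 58 percentage points higher from compound 1 to compound 3 (beyond the scatter), leaving compound 3 with the weakest effect of the three. Both substituted carbon-only rings give a stronger effect than the pyridin-3-yl ring, but this exchange brings in the ring nitrogen and removes the halogen or trifluoromethyl substituents in one step. Nothing at hand explains the size of these steps. The compounds shown leave open how much of the change belongs to the ring nitrogen and how much to the lost substituents. An unsubstituted phenyl ring and a chloro-substituted pyridin-3-yl ring at this position would separate the two.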